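This account rests on a few compounds, and the source may have more. Where it says the series, first, only, none or still open, it means among the compounds named here.

Compound 1 `CN1C(=S)N(c2ccccc2)C(=O)/C1=C\c1ccc(N(C)CCCO)cc1`: 2720 nM in an assay on isolated protein for inhibition of NADPH oxidase 2 (Homo sapiens), read by chemiluminescence, in the presence of a further agent that is not named here; on this read-out lower numbers stand for stronger inhibition and higher numbers for weaker inhibition
Compound 2 `CN1C(=S)N(c2ccccc2)C(=O)/C1=C\c1ccc(N(C)C)cc1O`: 3730 nM
Compound 3 `CCN(CC)c1ccc(/C=C2\C(=O)N(c3ccccc3)C(=S)N2C)c(O)c1`: 910 nM

Compound 3 gives the lowest number of the three in this assay; compound 1 stands nearest and compound 2 furthest from it. Compound 4 `CN1C(=S)N(c2ccccc2)C(=O)/C1=C\c1ccc(N(C)CCCO)cc1O` follows from compound 3 by (3-hydroxypropyl)(methyl)amino in place of diethylamino on an aromatic carbon. For the measured compounds named here, only one measured step touches the amino group: a 4.1-fold lower number from compound 2 to compound 3 (0.61 log units; beyond the scatter). The entering group is also carried by compound 1, whose number is higher than that of compound 3, though the two differ in more than one place. Compound 4 is therefore expected to give a higher number than compound 3, a step of a 2.4-fold higher number from compound 3 to compound 4 (0.38 log units; beyond the scatter). For compound 4 the estimate in this assay is 2200 nM, with a range from 700 nM to 6500 nM.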

Compound 4, half-maximal inhibitory concentration: 6330 nM
The estimate for compound 4 lay 2.9-fold (0.46 log units) below the measured number; low and high end bracket the measured number.
By their numbers in this assay, from the lowest: compound 3; then compounds 1, 2 and 4 (each within the scatter of the next, the first and the last beyond it).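

In this assay, this position on the ring does not accept every amino group alike: (3-hydroxypropyl)(methyl)amino in place of diethylamino gives a 7.0-fold higher number from compound 3 to compound 4 (0.84 log units; beyond the scatter). Adding 2-hydroxyethyl to the dimethylamino group gives no separable difference, a 1.7-fold higher number from compound 2 to compound 4 (0.23 log units; within the scatter), so this chain does not share the gain seen with diethylamino. With this chain in place, hydroxy in place of hydrogen on the aromatic carbon gives a 2.3-fold higher number from compound 1 to compound 4 (0.37 log units; beyond the scatter), the opposite of any gain. No measured evidence bears on the reason for these steps. Going by these compounds, whether the chain or its hydroxy group sets these numbers stays open, and a plain butyl group on the nitrogen would bear on that.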